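The source may report more compounds than this note shows. Statements on the series, on what has been measured and on what is new or still open speak of the compounds shown alone.

Values measured so far in a functional assay on the whole organism (strain Wistar) with Rattus norvegicus as the target, read by paw edema; on this read-out lower numbers stand for an effect already at smaller amounts and higher numbers for an effect only at larger amounts of compound
- compound 1 `CCC(=O)OCc1cc(-n2nc(C(F)(F)F)cc2-c2ccc(Br)cc2)ccc1S(N)(=O)=O` gives 17 mg/kg
- compound 2 `CCC(=O)OCc1cc(-n2nc(C(F)(F)F)cc2-c2ccc(OC)c(C)c2)ccc1S(N)(=O)=O` gives 10.9 mg/kg
- compound 3 `CCC(=O)OCc1cc(-n2nc(C(F)F)cc2-c2ccc(OC)c(C)c2)ccc1S(N)(=O)=O` gives 15 mg/kg

The number for compound 2 at 10.9 mg/kg lies within the usual scatter of both other compounds, so these three cannot be ranked. Compound 4 `CCC(=O)OCc1cc(-n2nc(C(F)(F)F)cc2-c2ccc3c(c2)CCO3)ccc1S(N)(=O)=O` has not been measured yet. The change from compound 2 to compound 4 is a group of 9 heavy atoms (8 carbon, 1 oxygen; one five-membered non-aromatic ring with 1 hetero atom, one six-membered aromatic ring of carbon only) in place of a group of 9 heavy atoms (8 carbon, 1 oxygen; one six-membered aromatic ring of carbon only), on an aromatic carbon and no other part of the structure differs. The entering group carries a five-membered non-aromatic ring that 4-methoxy-3-methylphenyl lacks. Within the data shown here, no measured compound has this ring, so the data say nothing about it directly.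

The closest evidence is a swap on the same aromatic carbon (a 1.6-fold lower number from compound 1 to compound 2 (0.19 log units; within the scatter)) in which 4-methoxy-3-methylphenyl took the place of 4-bromophenyl. The other measured step (a 1.4-fold higher number from compound 2 to compound 3 (0.14 log units; within the scatter)) puts hydrogen in place of fluoro in a different part of the molecule and bears on this change only loosely. Neither step leaves the scatter, so in this assay no step beyond the scatter is expected, and the expected change is small (a 1.1-fold higher number from compound 2 to compound 4 (0.04 log units; within the scatter)) with no firm direction. For compound 4 the estimated value is 12 mg/kg with an expected range from 6 mg/kg to 24 mg/kg for the coming measurement.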

Compound 4, dose for half-maximal effect: 8.5 mg/kg
The estimate for compound 4 lay 1.4-fold (0.15 log units) above the measured number; low and high end bracket the measured number.
By their numbers in this assay, from the lowest: compounds 4, 2, 3 and 1 (each within the scatter of the next).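

At this aromatic carbon of the five-membered aromatic ring with 2 nitrogen, the data now include a group carrying a five-membered non-aromatic ring with 1 hetero atom, and this assay shows a 1.3-fold lower number from compound 2 to compound 4 (0.11 log units; within the scatter) when this group replaces 4-methoxy-3-methylphenyl, which has the same count of heavy atoms. Measured against the smaller 4-bromophenyl group, the same ring gives a 2.0-fold lower number from compound 1 to compound 4 (0.30 log units; within the scatter) and this step also stays inside the usual scatter, so three different groups at this carbon now give numbers that cannot be told apart from their neighbours in the ranking. No measurement shown here accounts for this result.

The compounds leave open whether a group of a different kind at this carbon, such as a carboxylic acid, an amine or a plain phenyl ring with no substituent, would move the number beyond the scatter. On these data alone, it also remains open whether difluoromethyl in place of trifluoromethyl would behave alongside the new ring as it does in compound 3, and whether a ring of carbon only would serve in place of the ring with its oxygen.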